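Would One More Methoxy Help Compound 3?

The compounds below may be only part of what the source reports. "The series", "measured", "known", "first", "only" and "open" are said of these compounds alone.

Compound 1 `COc1ccc(-c2nc3cc(F)ccc3s2)cc1F` gives 20600 nM
Compound 2 `COc1ccc(-c2nc3cc(F)ccc3s2)cc1OC` gives 290 nM
Compound 3 `COc1cc(OC)cc(-c2nc3cc(F)ccc3s2)c1` gives 7550 nM

In a functional assay on KM12 cells (Homo sapiens) for antiproliferative activity (on this read-out lower numbers stand for stronger inhibition of growth and higher numbers for weaker inhibition of growth), compound 3 at 7550 nM stands in the middle of the three measured compounds. Compound 1 has a higher number and compound 2 a lower one, and both gaps lie beyond the scatter.

Compound 4 `COc1cc(-c2nc3cc(F)ccc3s2)cc(OC)c1OC` has not yet been measured. It differs from compound 3 by a single change (methoxy in place of hydrogen on an aromatic carbon) with methoxy in place of hydrogen on an aromatic carbon. Among the measured compounds shown here, one measured step bears on this: a 71-fold lower number from compound 1 to compound 2 (1.85 log units; beyond the scatter) is large and also brings in a methoxy. That methoxy replaces fluoro rather than hydrogen and sits elsewhere, so the step is only a loose guide. Compound 4 also carries all the methoxy groups of compound 2, which gives 290 nM in this assay as its value. A smaller move in the same direction therefore seems reasonable.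

The expected move is a 5.0-fold lower number from compound 3 to compound 4 (0.70 log units; beyond the scatter) as an estimate only. Compound 4 is estimated at 1500 nM with an expected range of 200 nM to 10000 nM as its two ends.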

Compound 4, concentration for 50% growth inhibition: 13000 nM
The estimate for compound 4 lay 8.7-fold (0.94 log units) below the measured number; measured number above the stated range.
By their numbers in this assay, from the lowest: compound 2; then compounds 3, 4 and 1 (each within the scatter of the next, the first and the last beyond it).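

In this assay, a methoxy in place of hydrogen on the aromatic carbon ortho to two methoxy groups and para to a large group gives a 1.7-fold higher number from compound 3 to compound 4 (0.24 log units; within the scatter), so on compound 3 this change does not separate the two compounds. Compound 4 also contains every methoxy of compound 2, yet one further methoxy gives a 45-fold higher number from compound 2 to compound 4 (1.65 log units; beyond the scatter), which shows that adding a methoxy can have very different outcomes depending on the methoxy groups already on the ring. No measurement here explains this contrast.

From the compounds shown here alone, whether this position tolerates only a methoxy or also other groups, such as a hydroxyl, an amine or a carboxylic acid, remains open. So does whether a longer chain, such as ethoxy, at this position would separate from compound 3.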